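Side-chain change from compound 2 to compound 3

A few compounds are considered here, and "the series" means these few. Any claim that something is new, unique, unknown or untested is made for them only; others in the source may bear on it.

In a functional assay on A549 cells (Homo sapiens) for antiproliferative activity, read by MTT assay, with a stated time of 48 h (on this read-out higher numbers stand for weaker inhibition and lower numbers for stronger inhibition), compound 2 (`CCN(CC)CCn1c(N)c(-c2nc3ccccc3n2C)c2nc(C#N)c(C#N)nc21`) reads > 50000 nM as a limit and not as a number. Compound 3 (`CN(C)CCCn1c(N)c(-c2nc3ccccc3n2C)c2nc(C#N)c(C#N)nc21`) carries (dimethylamino)methyl in place of diethylamino on a saturated chain carbon, two bonds along the chain from an aromatic nitrogen, which reads as 2-(diethylamino)ethyl to 3-(dimethylamino)propyl. Among the compounds with values here, the 3-(dimethylamino)propyl chain also stands on compound 1 (`CN(C)CCCn1c(N)c(-c2nc3ccccc3[nH]2)c2nc(C#N)c(C#N)nc21`), which gives 10400 nM as the only number so far. In this assay a moderate step toward stronger inhibition is expected (an at least 2.0-fold lower number from compound 2 to compound 3 (0.30 log units; that floor lies within the scatter)) and a further limit remains possible. For compound 3 the estimated value is 25000 nM with an expected range (8000 nM to 70000 nM).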

Compound 3, half-maximal inhibitory concentration: 11700 nM
Compound 3: middle estimate off by 2.1-fold (0.33 log units), on the high side; the measured number falls inside the stated range.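

In this assay, 3-(dimethylamino)propyl in place of 2-(diethylamino)ethyl on the aromatic nitrogen of the shared core gives an at least 4.2-fold lower number from compound 2 to compound 3 (0.63 log units; beyond the scatter). Compound 2 sits at a limit of the assay and not at a number, so this step is only a floor: the limit of > 50000 nM in this assay, at which 1 of the 3 values shown sits. With the 3-(dimethylamino)propyl chain held constant, a 1.1-fold higher number from compound 1 to compound 3 (0.05 log units; within the scatter), so hydrogen and methyl on that other aromatic nitrogen do not separate here.

Chain length and the groups on the amine change together in the first step, so which of them carries it remains open. A 2-(dimethylamino)ethyl chain on the core of compound 3 would separate the two.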